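Working notes: solubility across four related compounds

The compounds below may be only part of what the source reports. "The series", "measured", "known", "first", "only" and "open" are said of these compounds alone.

Compound 1 `O=C(O)CC[C@H](NC(=O)CNC(=O)NC1CCCCC1)C(=O)O` and compound 2 `CC(C)[C@H](NC(=O)CNC(=O)NC1CCCCC1)C(=O)O` share one core and differ in a single place: isopropyl in place of 2-carboxyethyl on a saturated chain carbon bound to an amide-type nitrogen and a carbonyl carbon. In a physicochemical assay for solubility, in phosphate buffer, at pH 7.4 (on this read-out lower numbers stand for lower solubility and higher numbers for higher solubility), compound 1 gives > 500000 nM, which is a limit of the assay and not a number. In this assay compound 2 gives > 500000 nM, again a limit. The step between the two is therefore a step that the two limits leave unreadable from compound 1 to compound 2.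

Compound 3 `O=C(O)CC[C@H](NC(=O)CCCCCNC(=O)NC1CCCCC1)C(=O)O` carries a different core; the difference between the core of compound 1 and the core of compound 3 is not broken down here. In this assay compound 3 gives > 500000 nM, once more a limit. Taken together, (the limit of > 500000 nM in this assay, at which 3 of the 3 values shown sit).

Compound 4 `CC(C)[C@H](NC(=O)CCCCCNC(=O)NC1CCCCC1)C(=O)O` has not been measured in this assay. It stands to compound 3 as compound 2 stands to compound 1: isopropyl in place of 2-carboxyethyl on a saturated chain carbon bound to an amide-type nitrogen and a carbonyl carbon. The place of the change reads the same word for word in both pairs, so this is the same change made on the second core. The step that the two limits leave unreadable from compound 1 to compound 2 carries no readable size, so it sets no size for the change on the core of compound 3. The expectation for compound 4 rests instead on compound 3 giving > 500000 nM and on (the limit of > 500000 nM in this assay, at which 3 of the 3 values shown sit). The step expected from the measured parent is a number no higher from compound 3 to compound 4 (the limit leaves the size open). Compound 4 is estimated at 500000 nM, with a range from 250000 nM to 1000000 nM, and is expected most likely to be reported again as a limit rather than a number.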

Compound 4, solubility: > 500000 nM
Compound 4: no number, only a limit (the forecaster's own chance of this, stated with the estimate: 85%); the middle value sits exactly at the limit.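

In this assay compound 4 gives > 500000 nM, which is a limit and not a number. Compound 3 also sits at a limit, so no new step can be read between compound 3 and compound 4. The compounds shown leave open the actual solubility of each compound, and so the size of the change from 2-carboxyethyl to isopropyl on either core: the limit of > 500000 nM in this assay, at which 4 of the 4 values shown sit.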